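Replacing 2-methylpyridin-3-yl in compound 1

This account rests on a few compounds, and the source may have more. Where it says the series, first, only, none or still open, it means among the compounds named here.

Measured in an ADME assay on microsomes from liver (Rattus norvegicus) for metabolic stability; a higher number here means that the compound lasts longer, a lower number that the compound disappears faster:
- compound 1 `CC#C[C@@H](Cc1nnn[nH]1)c1ccc(OCc2ccc3scc(-c4cccnc4C)c3c2)cc1`: 0.183 h
- compound 2 `CC#C[C@@H](Cc1nnn[nH]1)c1ccc(OCc2cc(Cl)c3scc(-c4ccccc4C)c3c2)cc1`: 0.117 h
- compound 3 `CC#C[C@@H](Cc1nnn[nH]1)c1ccc(OCc2ccc3sc(C#N)c(-c4ccccc4C)c3c2)cc1`: 0.533 h

Compound 1 stays within the scatter of compound 2, and compound 3 lies beyond the scatter of compound 1 on the higher side. Compound 4 `CC#C[C@@H](Cc1nnn[nH]1)c1ccc(OCc2ccc3scc(-c4ccccc4C(F)(F)F)c3c2)cc1` has not yet been measured. It carries 2-(trifluoromethyl)phenyl in place of 2-methylpyridin-3-yl on an aromatic carbon. For the measured compounds named here, no measured pair differs in only one place, so the data offer no direct guide to this change. In this assay, no step beyond the scatter is expected. The estimated step of a 1.1-fold higher number from compound 1 to compound 4 (0.04 log units; within the scatter) is small and points slightly upward. For compound 4, the expected half-life is 0.2 h, with an estimated range from 0.09 h to 0.45 h.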

Compound 4, half-life: 0.167 h
Compound 4: the middle estimate sits 1.2-fold (0.08 log units) above what was measured; low and high end bracket the measured number.
By their numbers in this assay, from the lowest: compounds 2, 4 and 1 (each within the scatter of the next); then compound 3.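

Compound 1 and compound 4 form the only pair shown that differs in one place, and in this assay the exchange on this aromatic carbon, two ring bonds from the ring sulfur, gives a 1.1-fold lower number from compound 1 to compound 4 (0.04 log units; within the scatter) for 2-(trifluoromethyl)phenyl in place of 2-methylpyridin-3-yl. The half-life thus does not separate the two groups, although the ring of the entering group is of carbon only. No measurement at hand offers a reason for this result. On these data alone, whether an amine or a carboxylic acid on this ring would give a half-life in the same range remains open. So does whether the same exchange would behave alike with the chloro or nitrile substituents of the other compounds.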